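This account rests on a few compounds, and the source may have more. Where it says the series, first, only, none or still open, it means among the compounds named here.

Measured compounds in a functional assay on HCT-116 cells (Homo sapiens) for antiproliferative activity, read by MTT assay; a higher number here means a weaker inhibitor, a lower number a stronger inhibitor:
compound 1, `COc1cccc(/C=N/Nc2ncc3c(n2)n(C2CCCC2)c(=O)c(=O)n3C)c1`, gives 45800 nM;
compound 3, `Cn1c(=O)c(=O)n(C2CCCC2)c2nc(N/N=C/c3cc([N+](=O)[O-])ccc3Cl)ncc21`, gives 5610 nM;
compound 2, `COc1ccc(/C=N/Nc2ncc3c(n2)n(C2CCCC2)c(=O)c(=O)n3C)c(OC)c1`, reaches only a limit of the assay, > 100000 nM, and not a number.

Among the two numbers available, compound 1 stands at the higher one; its nearest neighbour is compound 3, with an 8.2-fold lower number from compound 1 to compound 3 (0.91 log units; beyond the scatter). Compound 2 sits at the limit (the limit of > 100000 nM in this assay, at which 1 of the 3 values shown sits), so the step of an at least 2.1-fold higher number from compound 1 to compound 2 (0.33 log units; beyond the scatter) is known only as a bound, and an at least 17-fold lower number from compound 2 to compound 3 (1.25 log units; beyond the scatter) likewise.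

The unmeasured compound 4, `CSc1ccc(/C=N/Nc2ncc3c(n2)n(C2CCCC2)c(=O)c(=O)n3C)cc1`, differs from compound 1 only at the aryl group on the hydrazone carbon: 4-(methylsulfanyl)phenyl in place of 3-methoxyphenyl on a carbon with a double bond to nitrogen. Within the data shown here, no measured step exchanges a methoxy for a methylsulfanyl group, so none bears on this change directly. What the measured steps show is that the aryl substituent pattern can shift this assay in either direction: a second methoxy group in compound 2 raised the number at least modestly, while the chloro-nitro pattern of compound 3 lowered it modestly. A single para substituent of similar size gives no ground to expect a shift beyond the scatter in this assay; compound 4 is therefore estimated close to compound 1, with a 1.1-fold lower number from compound 1 to compound 4 (0.06 log units; within the scatter). Compound 4 is expected to give about 40000 nM, within 12000 nM to 130000 nM.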

Compound 4, half-maximal inhibitory concentration: 9010 nM
The estimate for compound 4 lay 4.4-fold (0.65 log units) above the measured number, and the stated range ends above it.
By their numbers in this assay, from the lowest: compounds 3 and 4 (each within the scatter of the next); then compound 1. At a limit, above all of these: compound 2.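

In this assay, among these compounds, the step of a 5.1-fold lower number from compound 1 to compound 4 (0.71 log units; beyond the scatter) comes from an exchange that leaves the counts of heavy atoms, hydrogen-bond donors and hydrogen-bond acceptors unchanged, with no net charge on either group, yet it lies beyond the scatter; the earlier steps all changed the number of substituents on the aryl group. The step of a 1.6-fold higher number from compound 3 to compound 4 (0.21 log units; within the scatter) lies within the scatter, which shows that 4-(methylsulfanyl)phenyl, with its single substituent, is not separated in this series from the doubly substituted 2-chloro-5-nitrophenyl. Compound 2 remains at a limit of the assay and not at a number, and so an at least 11-fold lower number from compound 2 to compound 4 (1.04 log units; beyond the scatter) is known only as a bound: the limit of > 100000 nM in this assay, at which 1 of the 4 values shown sits.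

As far as these compounds go, the exchange between compound 1 and compound 4 alters both the heteroatom and its place on the ring, and how much of the step belongs to each stays open; 4-methoxyphenyl and 3-(methylsulfanyl)phenyl groups on the same carbon would separate the two. Also open, from the compounds shown here alone, is how an amine or a carboxylic acid on this aryl group would read in this assay.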